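Tolerated concentration of a methyl-extended pyrimidinone analogue

The compounds below may be only part of what the source reports. "The series", "measured", "known", "first", "only" and "open" are said of these compounds alone.

Compound 1 `CCCSc1nc(Cc2c(F)cccc2Cl)cc(=O)[nH]1` and compound 2 `CCC(C)Sc1nc(Cc2c(F)cccc2Cl)cc(=O)[nH]1` were both examined in an ADME assay on MT4 cells (Homo sapiens) for activation, read by MTT assay; a higher number here means that more compound is tolerated, a lower number that less compound is tolerated. Compound 1 gives in this assay > 80000 nM, which is a limit of the assay rather than a number. Compound 2 gives in this assay > 76000 nM, likewise a limit of the assay. The change between them is methyl in place of hydrogen on a saturated chain carbon bound to a saturated chain carbon and a sulfur and the resulting step, a step that the two limits leave unreadable from compound 1 to compound 2, cannot be sized because both values sit at limits, as the limit of > 80000 nM in this assay, at which 1 of the 3 values shown sits, and the limit of > 76000 nM in this assay, at which 1 of the 3 values shown sits, show.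

Compound 3 `Cc1c(C(C)c2c(F)cccc2Cl)nc(SC(C)C)[nH]c1=O` carries a different core; the difference between the two cores is not broken down here. In this assay compound 3 gives > 15000 nM, a limit of the assay and not a number, as the limit of > 15000 nM in this assay, at which 1 of the 3 values shown sits, records.

Compound 4 `CCc1c(C(C)c2c(F)cccc2Cl)nc(SC(C)C)[nH]c1=O` has not yet been measured in this assay. It differs from compound 3 by methyl in place of hydrogen on a saturated chain carbon bound to an aromatic carbon. This is the same kind of change as that from compound 1 to compound 2, but not the same: there the place is on a saturated chain carbon bound to a saturated chain carbon and a sulfur, whereas here it is on a saturated chain carbon bound to an aromatic carbon. Since the earlier step of this kind left both values at limits, no size can be carried over. The expected step that the limit leaves unreadable from compound 3 to compound 4 therefore rests only on compound 3 remaining at a limit in this assay. Compound 4 is estimated to give 30000 nM in this assay.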

Compound 4, half-maximal cytotoxic concentration: > 3000 nM
Compound 4: no number, only a limit; the forecaster's own chance of this, stated with the estimate: 75%; the middle value lies beyond the limit too.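

In this assay compound 4 gives > 3000 nM, which is a limit of the assay and not a number. No step can be read between compound 3 and compound 4, as both values are limits: the limit of > 3000 nM in this assay, at which 1 of the 4 values shown sits.

The compounds shown leave open what concentration any of them is actually tolerated at, and whether methyl in place of hydrogen changes it at either place.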